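Formyl to ethynyl on the shared core

This account rests on a few compounds, and the source may have more. Where it says the series, first, only, none or still open, it means among the compounds named here.

Of the compounds shown here, two have been measured in a functional assay on DU-145 cells (Homo sapiens) for cytotoxicity, read by MTT assay, with a stated time of 48 h; a lower number here means a stronger inhibitor, a higher number a weaker inhibitor. Compound 1 `C=C1CC[C@@H](C(C)C)[C@]12CC=C(C=O)CC2` gives 165000 nM in this assay. Compound 2 `CC1(C)CCCC2=CC=C(C=O)CC[C@]21C` gives 191000 nM in this assay. Compound 1 has the lower of the two numbers, but its gap to compound 2 lies within the scatter, so the two read as equal and neither can be called the stronger inhibitor. Both numbers sit where inhibition is weak.

Compound 3 `C#CC1=CC[C@]2(CC1)C(=C)CC[C@H]2C(C)C` is not yet measured. It differs from compound 1 in one place: ethynyl in place of formyl on a double-bonded ring carbon. The change sits on a double-bonded ring carbon of a six-membered non-aromatic ring of carbon only, joined to another ring at one shared atom. Going by the values given here, no step between measured compounds touches this position, so there is no measured precedent for the swap. Since compound 1 gives 165000 nM and compound 2 gives 191000 nM, both weak, the step is expected to be small, toward a weaker inhibitor if anything, or none beyond the scatter. The expected step is a 1.3-fold higher number from compound 1 to compound 3 (0.12 log units; within the scatter). Compound 3 is estimated to give 220000 nM, within a range of 90000 nM to 550000 nM.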

Compound 3, half-maximal inhibitory concentration: 121000 nM
Compound 3: the middle estimate sits 1.8-fold (0.26 log units) above what was measured; low and high end bracket the measured number.
By their numbers in this assay, from the lowest: compounds 3, 1 and 2 (each within the scatter of the next).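

Ethynyl in place of formyl on a double-bonded ring carbon gives a 1.4-fold lower number from compound 1 to compound 3 (0.13 log units; within the scatter) in this assay, the only step shown at this position of the shared core, and it stays within the scatter. Formyl carries a hydrogen-bond acceptor and an oxygen while ethynyl carries neither, so on the core of compound 1 this assay tolerates their loss at this position without a step beyond the scatter, and compound 3 reads as equal to compound 1. No measured evidence bears on why the two compounds read alike.

As far as these compounds go, whether this position is simply indifferent to its substituent or the readout gives little room to see a difference remains open, since all the numbers shown sit where inhibition is weak and this single swap cannot separate the two readings. A carboxylic acid, an amine or a longer chain on the same double-bonded ring carbon would test whether any group there moves the number beyond the scatter in either direction.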